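The source may report more compounds than this note shows. Statements on the series, on what has been measured and on what is new or still open speak of the compounds shown alone.

Compound 2 `COC[C@H](C)[C@@H](C)C(c1ccc(O)c(OC)c1)c1ccc(O)c(OC)c1` is the point of departure. In a functional assay on HL-60 cells (Homo sapiens) for cytotoxicity, read by WST assay, with a stated time of 48 h (on this read-out higher numbers stand for weaker inhibition and lower numbers for stronger inhibition), compound 2 gives 68000 nM, the highest of the three numbers, although compound 1 `COc1ccc(C(c2ccc(OC)c(OC)c2)[C@H](C)[C@@H](C)CO)cc1OC` gives 47000 nM, within the scatter of it, while compound 3 `COc1cc(C(c2ccc(O)c(OC)c2)[C@H](CC(C)C)C(C)C)ccc1O` gives 9600 nM. Within the data shown here, the only step recorded, a 7.1-fold lower number from compound 2 to compound 3 (0.85 log units; beyond the scatter), exchanges the whole side chain and says nothing about configuration. Compound 4 `COC[C@@H](C)[C@@H](C)C(c1ccc(O)c(OC)c1)c1ccc(O)c(OC)c1` differs from compound 2 only in this way: the two compounds have the same atoms and bonds and differ only in configuration as drawn: 1 of 2 stereo elements differ; a stereocentre at a saturated chain carbon is drawn R in compound 2 and S in compound 4. Among the measured compounds shown here, no measured step in this assay concerns a change of configuration alone, so nothing in the data predicts a shift, and for no change at the digits printed from compound 2 to compound 4 (within the scatter) a step within the scatter is expected. Compound 4 is therefore expected to give about 68000 nM in this assay, between 30000 nM and 150000 nM.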

Compound 4, half-maximal inhibitory concentration: 85000 nM
Compound 4: middle estimate off by 1.3-fold (0.10 log units), on the low side; measured number inside the range.
By their numbers in this assay, from the lowest: compound 3; then compounds 1, 2 and 4 (each within the scatter of the next).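

The comparison isolates configuration at one centre: the fact that compounds 2 and 4 differ only in the configuration as drawn. In this assay, changing this saturated chain carbon from R to S gives a 1.3-fold higher number from compound 2 to compound 4 (0.10 log units; within the scatter), so this centre shows no effect beyond the scatter in the 2-(methoxymethyl)-1-methylpropyl series. The side-chain exchange remains beyond the scatter with the S form, at an 8.9-fold higher number from compound 3 to compound 4 (0.95 log units; beyond the scatter), so the larger step seen so far is not confined to the R form.

Open, as far as these compounds go, is whether the second stereocentre behaves the same way. Also open, from the compounds shown here alone, is how an amine or a carboxylic acid in place of the terminal methoxy group would read.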